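The source may report more compounds than this note shows. Statements on the series, on what has been measured and on what is new or still open speak of the compounds shown alone.

Measured compounds:
compound 1 `COc1cc(C)cc(-c2c(-c3ccnc(-c4ccc(C(C)=O)cc4)c3)cnn2CC#N)c1` — 12%
compound 2 `Cc1cc(O)cc(-c2nn(CC#N)cc2-c2ccnc(-c3ccc(Oc4ccccc4)cc3)c2)c1` — -34%

In a functional assay on HCT-15 cells (Homo sapiens) for cytotoxicity, read by sulforhodamine B assay, with a stated time of 48 h, tested at 1 uM (on this read-out lower numbers stand for a stronger effect and higher numbers for a weaker effect at the one concentration tested), compound 2 gives -34%, the lowest of the two numbers recorded; the nearest is compound 1, which gives 12%, a gap beyond the usual scatter. Going by the values given here, the two compounds differ in several places at once, so the numbers say only that compound 2 shows the stronger effect of the pair, and no single change is attached to that gap.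

Compound 3 `Cc1cc(O)cc(-c2nn(CC#N)cc2-c2ccnc(-c3ccc(N(C)C)cc3)c2)c1` is not yet measured. Compared with compound 2 its change is dimethylamino in place of phenoxy on an aromatic carbon. Among the compounds with values here, no measured pair covers this change or anything close to it, so there is no step to lean on; the expectation rests on compound 2 alone, as the only compound with the same remaining structure, and on the absence of any example where a group in that place is exchanged. The step from compound 2 is therefore expected to be modest, most likely toward a weaker effect, though a step within the scatter cannot be ruled out, a number 24 percentage points higher from compound 2 to compound 3 (beyond the scatter) being the estimated size. For compound 3 the expected value in this assay is -10%, in the range -45% to 25%.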

Compound 3, a percentage reported as activity, at one concentration (the size of the read-out at that concentration, not a potency): 14%
The estimate for compound 3 lay 24 percentage points below the measured number; the measured number falls inside the stated range.
By their numbers in this assay, from the lowest: compound 2; then compounds 1 and 3 (each within the scatter of the next).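

Going by these compounds alone, this is the first single-place step. With the rest of the structure held fixed, dimethylamino in place of phenoxy on an aromatic carbon, para to a large group, gives a number 48 percentage points higher from compound 2 to compound 3 (beyond the scatter) in this assay, so the read-out at this position depends on the group it carries. The stronger effect stands with the phenoxy compound, which has the larger group and the six-membered aromatic ring of carbon only, while the two groups do not differ in their counted hydrogen-bond donors and acceptors; no measured property at hand accounts for the step.

Open, going by these compounds, is whether the effect follows the aromatic ring or simply the size of the group: a benzyloxy, phenylamino or methoxy group in the same place would separate these readings. Also open, on these data alone, is whether the weaker effect extends to other amines, such as a primary amine or a morpholine, and how this single step at one concentration would translate into a potency difference.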